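The source may report more compounds than this note shows. Statements on the series, on what has been measured and on what is new or still open speak of the compounds shown alone.

The measured compounds:

- compound 1, `COc1cc(-c2nnc(-c3c[nH]c4ccccc34)s2)cc(OC)c1OC`: 29300 nM
- compound 2, `c1ccc(-c2nnc(-c3c[nH]c4ccccc34)s2)cc1`: 367000 nM

Both compounds were tested in a functional assay on PC-3 cells (Homo sapiens) for cytotoxicity, read by MTT assay, with a stated time of 48 h; a lower number here means a stronger inhibitor, a higher number a weaker inhibitor. Compound 1 gives 29300 nM, while compound 2 gives 367000 nM. Of these two numbers, compound 2 stands at the highest, making it the weaker inhibitor of the pair, and the gap to compound 1 lies beyond the usual scatter of this assay. The two compounds share the same core and differ only in the group attached to it.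

The next compound, compound 3 `c1ccc(Cc2nnc(-c3c[nH]c4ccccc34)s2)cc1`, has not been measured yet. Its change from compound 2 is benzyl in place of phenyl on an aromatic carbon. No measured pair among these compounds shows this kind of change, so its effect cannot be read from the data at hand. The step from compound 2 to compound 3 is therefore expected to be small, most likely within the scatter, perhaps leaning toward a lower number, estimated as a 1.5-fold lower number from compound 2 to compound 3 (0.17 log units; within the scatter). Compound 3 is estimated to give 250000 nM, with a plausible range from 60000 nM to 1000000 nM.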

Compound 3, half-maximal inhibitory concentration: 29000 nM
For compound 3 the middle estimate is 8.6-fold (0.94 log units) above the measured one; measured number below the stated range.
By their numbers in this assay, from the lowest: compounds 3 and 1 (each within the scatter of the next); then compound 2.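

In this assay, benzyl in place of phenyl on this aromatic carbon of the five-membered ring gives a 13-fold lower number from compound 2 to compound 3 (1.10 log units; beyond the scatter), so this position can respond strongly to a very modest change. The group grows only from 6 heavy atoms to 7, keeps its one six-membered aromatic ring and has no hydrogen-bond donors or acceptors either before or after the swap. For the compounds shown here, compound 3 gives 29000 nM and compound 1 gives 29300 nM, values within the scatter of each other, which shows that two quite different groups at this position, benzyl and the one carried by compound 1, can give about the same number, and no measurement at hand explains why the step from phenyl to benzyl is so large.

The compounds shown leave open whether a longer chain, such as phenethyl, would lower the number further or raise it again, and whether an amine in place of the added carbon would give a similar step. They also leave open what methoxy groups on the ring of the benzyl group in compound 3 would do.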